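Compound 2 to compound 3: dimethylamino on the shared core

A few compounds are considered here, and "the series" means these few. Any claim that something is new, unique, unknown or untested is made for them only; others in the source may bear on it.

- compound 1 `COc1cc(-c2cnn3cc(OC)c(-c4cnn(C)c4)nc23)ccn1`: 56%
- compound 2 `COc1cc(-c2cnn3cc(OC)c([C@@H]4COC(C)(C)C4)nc23)ccn1`: 30%

In an ADME assay on microsomes from liver (Rattus norvegicus) for metabolic stability, with a stated time of 60 min, tested at 1 uM (on this read-out lower numbers stand for a less stable compound and higher numbers for a more stable compound), compound 2 holds the lower of the two numbers, 30%. Compound 3 `COc1cc(-c2cnn3cc(OC)c(N(C)C)nc23)ccn1` differs from compound 2 in one place: a group of 3 heavy atoms (2 carbon, 1 nitrogen; no ring) in place of a group of 7 heavy atoms (6 carbon, 1 oxygen; one five-membered non-aromatic ring with 1 hetero atom), on an aromatic carbon. For the measured compounds named here, the only measured step at this place is a number 26 percentage points lower from compound 1 to compound 2 (beyond the scatter), which is modest and beyond the scatter. Going by the values given here, no measured compound carries dimethylamino, so that step is only a loose guide to size. The step expected in this assay is a number 12 percentage points higher from compound 2 to compound 3 (beyond the scatter), upward and modest, and possibly within the scatter. The estimate for compound 3 is 42%, with an expected range from 22% to 65%.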

Compound 3, percent of the compound remaining: 3%
Estimate against measurement, compound 3: 39 percentage points above, outside the stated range (below it).
By their numbers in this assay, from the lowest: compound 3; then compound 2; then compound 1.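

At this aromatic carbon, dimethylamino gives a number 27 percentage points lower from compound 2 to compound 3 (beyond the scatter) in this assay, and a number 53 percentage points lower from compound 1 to compound 3 (beyond the scatter). Going from either ring-bearing group to a group with no ring therefore does not bring stability back, and the aromatic 1-methyl-1H-pyrazol-4-yl stands well above dimethylamino. Nothing on hand explains this fall.

From the compounds shown here alone, whether a cyclic amine such as morpholine or pyrrolidine, or a methylamino group, would read like dimethylamino stays open. So does whether the fall follows the amine nitrogen on this carbon or the missing ring.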